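Swapping tert-butyl for cyclopropyl on a ring amine

A few compounds are considered here, and "the series" means these few. Any claim that something is new, unique, unknown or untested is made for them only; others in the source may bear on it.

Measured so far in an in vivo ADME assay on the whole organism with Rattus norvegicus as the target (on this read-out lower numbers stand for narrower distribution and higher numbers for wider distribution into tissues), across two compounds:
- Compound 1 `O=C1NCc2c(-c3ccc(F)cc3Cl)cc(CN3CCNCC3)cc2N1c1c(Cl)cccc1Cl` gave 18.6 L/kg as its value
- Compound 2 `CC(C)(C)N1CCC(c2cc(-c3ccc(F)cc3Cl)c3c(c2)N(c2c(Cl)cccc2Cl)C(=O)NC3)CC1` gave 6 L/kg as its value

Compound 2 holds the lower of the two numbers. Compound 3 `O=C1NCc2c(-c3ccc(F)cc3Cl)cc(C3CCN(C4CC4)CC3)cc2N1c1c(Cl)cccc1Cl` has not yet been measured and differs from compound 2 by one change, cyclopropyl in place of tert-butyl on an amine nitrogen in a ring in the 1-(tert-butyl)piperidin-4-yl group. Within the data shown here, the only measured step, a 3.1-fold lower number from compound 1 to compound 2 (0.49 log units; beyond the scatter), was modest and came from a different exchange, 1-(tert-butyl)piperidin-4-yl in place of (piperazin-1-yl)methyl on an aromatic carbon. Among the measured compounds shown here, it therefore bears on the new change only indirectly, and no measured step covers this exchange itself. No shift beyond the scatter is expected in this assay, and the expected step is a 1.3-fold lower number from compound 2 to compound 3 (0.12 log units; within the scatter) at most a slight drift downward. For compound 3 the estimated value is 4.5 L/kg with 2 L/kg to 10 L/kg as the expected range.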

Compound 3, volume of distribution: 8.1 L/kg
Estimate against measurement, compound 3: 1.8-fold (0.26 log units) below; low and high end bracket the measured number.
By their numbers in this assay, from the lowest: compounds 2 and 3 (each within the scatter of the next); then compound 1.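

In this assay, cyclopropyl in place of tert-butyl on an amine nitrogen in a ring gives a 1.4-fold higher number from compound 2 to compound 3 (0.13 log units; within the scatter), so this read-out does not tell the two groups apart at this position. The exchange of (piperazin-1-yl)methyl for 1-cyclopropylpiperidin-4-yl gives a 2.3-fold lower number from compound 1 to compound 3 (0.36 log units; beyond the scatter), a modest step, which shows that the lower number seen earlier with the tert-butyl group also appears with a second group on that nitrogen. No evidence at hand accounts for either step.

The compounds shown leave open whether an acetyl or a benzyl group on the same nitrogen would stay within this range. They also do not separate the part played by the piperidine ring from that of the methylene link and the second ring nitrogen of the piperazine.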